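Swapping Chloro for Nitro on the Shared Core

The source may hold more compounds than are shown below. What is called first, only, known or untested is meant among the compounds shown, and "the series" means these compounds.

Compound 1, `c1ccc(-c2nnc(Nc3ncccn3)o2)cc1`: 51.4%
Compound 2, `Clc1ccccc1-c1nnc(Nc2ncccn2)o1`: < 20%

In a functional assay, with a stated time of 30 min, tested at 20 uM (a higher number here means more inhibition at the concentration tested (going by the name of the read-out), a lower number less inhibition), compound 1 gives 51.4%. Compound 2 sits at a limit of the assay rather than a number, < 20%, as shown by the limit of < 20% in this assay, at which 1 of the 2 values shown sits. The measured step of a number at least 31.4 percentage points lower from compound 1 to compound 2 (beyond the scatter) is the only one that bears on the new change. Compound 3, `O=[N+]([O-])c1ccccc1-c1nnc(Nc2ncccn2)o1`, differs from compound 2 by nitro in place of chloro on an aromatic carbon. Since compound 2 already stands at the limit, a further substituent at the same place is expected to leave compound 3 near that limit, with an estimated step that the limit leaves unreadable from compound 2 to compound 3. Compound 3 is therefore estimated at 18%, between 5% and 35%.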

Compound 3, a percentage reported as inhibition, at one concentration (the size of the read-out at that concentration, not a potency): 51.8%
For compound 3 the middle estimate is 33.8 percentage points below the measured one; measured number above the stated range.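

In this assay, a substituent on an aromatic carbon of this six-membered ring, ortho to a large group, does not always cost inhibition: nitro in place of chloro gives a number at least 31.8 percentage points higher from compound 2 to compound 3 (beyond the scatter) here. Nitro in place of hydrogen gives a number 0.4 percentage points higher from compound 1 to compound 3 (within the scatter) on the shared core, so the outcome at this place depends on which group enters. The exact size of the chloro-to-nitro step cannot be read because compound 2 stands at a limit: the limit of < 20% in this assay, at which 1 of the 3 values shown sits.

As far as these compounds go, whether an amine or a methoxy group at this place would track nitro or chloro stays open. So does whether nitro would behave the same way elsewhere on the ring.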